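Pentylselanyl to Methylsulfanyl on a Quinazoline Cytotoxicity Series

The source may hold more compounds than are shown below. What is called first, only, known or untested is meant among the compounds shown, and "the series" means these compounds.

Measured compounds:
compound 1 `CCCCC[Se]c1nc(N)c2ccccc2n1`: 15300 nM
compound 2 `CCCCC[Se]c1nc([Se]CCCCC)c2ccccc2n1`: 71300 nM
compound 3 `CCCCC[Se]c1nc(NCc2ccccc2)c2ccccc2n1`: 70900 nM

In an ADME assay on 184B5 cells (Homo sapiens) for cytotoxicity, read by MTT assay, with a stated time of 72 h (on this read-out lower numbers stand for stronger inhibition of growth and higher numbers for weaker inhibition of growth), compound 3 gives 70900 nM. Compound 3 stands second highest of the three numbers; its nearest neighbour is compound 2, the two being within the scatter (a 1.0-fold lower number from compound 2 to compound 3 (0.00 log units; within the scatter)), and its furthest is compound 1 (a 4.6-fold higher number from compound 1 to compound 3 (0.67 log units; beyond the scatter)).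

Compound 4 `CSc1nc(NCc2ccccc2)c2ccccc2n1` differs from compound 3 in one place: a group of 2 heavy atoms (1 carbon, 1 sulfur; no ring) in place of a group of 6 heavy atoms (5 carbon, 1 selenium; no ring), on an aromatic carbon.

Going by the values given here, none of the measured steps exchanges one such chain for another at this position. The two steps beyond the scatter, a 4.7-fold higher number from compound 1 to compound 2 (0.67 log units; beyond the scatter) and a 4.6-fold higher number from compound 1 to compound 3 (0.67 log units; beyond the scatter), each add a group where compound 1 carries a hydrogen or a nitrogen, and the remaining step, a 1.0-fold lower number from compound 2 to compound 3 (0.00 log units; within the scatter), is within the scatter. Among the compounds with values here, no precedent therefore tells the direction for the change from compound 3 to compound 4, and the expectation is for no step beyond the scatter in this assay, that is a 1.1-fold higher number from compound 3 to compound 4 (0.02 log units; within the scatter).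

Compound 4 is estimated to give 75000 nM in this assay, with a range from 25000 nM to 200000 nM.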

Compound 4, concentration for 50% growth inhibition: 28900 nM
For compound 4 the middle estimate is 2.6-fold (0.41 log units) above the measured one; low and high end bracket the measured number.
By their numbers in this assay, from the lowest: compounds 1 and 4 (each within the scatter of the next); then compounds 3 and 2 (each within the scatter of the next).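

With the benzylamino group held in place, the carbon between two ring nitrogen atoms turns out to be a place where the read-out moves in this assay: methylsulfanyl in place of the group of 6 heavy atoms gives a 2.5-fold lower number from compound 3 to compound 4 (0.39 log units; beyond the scatter), a modest step towards stronger inhibition of growth. Going by these compounds alone, it is the first step at this place alone, as every earlier step changed the other substituent while the group of 6 heavy atoms stayed where it was. No measurement in hand accounts for the direction or the size of this step.

The exchange replaces selenium with sulfur and shortens the chain at once, so this pair cannot say which of the two changes carries the step; a methylselanyl or a pentylsulfanyl group on the same benzylamino compound would separate them. Also open, from the compounds shown here alone, is whether methylsulfanyl would give a step of the same direction with the free amino group of compound 1 at the other place, and how a chain of intermediate length, such as propylsulfanyl, would read here.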